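The source may hold more compounds than are shown below. What is called first, only, known or untested is meant among the compounds shown, and "the series" means these compounds.

Compound 1 `COc1cc(-c2nnc3n2NC(c2ccco2)C(C(=O)c2cccs2)S3)cc(OC)c1OC` carries a (thiophen-2-yl)carbonyl on a saturated ring carbon of the shared core. In a functional assay on MCF7 cells (Homo sapiens) for cytotoxicity, read by MTT assay, with a stated time of 48 h (a lower number here means a stronger inhibitor, a higher number a weaker inhibitor), compound 1 gives > 100000 nM, which is a limit of the assay rather than a number. Compound 2 `COc1cc(-c2nnc3n2NC(c2cccs2)C(C(=O)c2ccccc2)S3)cc(OC)c1OC` has a closely related core. In this assay compound 2 gives > 100000 nM, again a limit of the assay. Compound 3 `COc1ccc(C(=O)C2Sc3nnc(-c4cc(OC)c(OC)c(OC)c4)n3NC2c2cccs2)cc1` differs from compound 2 by a methoxy in place of hydrogen on an aromatic carbon, and in this assay compound 3 gives 49500 nM. Among the compounds with values here, the only measured step, an at least 2.0-fold lower number from compound 2 to compound 3 (0.30 log units; that floor lies within the scatter), concerns that methoxy and not the group on the carbonyl carbon; it also starts from the limit of > 100000 nM in this assay, at which 2 of the 3 values shown sit, so its true size is uncertain. Compound 4 `COc1cc(-c2nnc3n2NC(c2ccco2)C(C(=O)c2cccc4ccccc24)S3)cc(OC)c1OC` arises from compound 1 by naphthalen-1-yl in place of thiophen-2-yl on a carbonyl carbon. Within the data shown here, no measured step touches this exchange, so no direction is indicated by the data. Compound 4 is therefore expected to stay weak, with an estimated 100000 nM (range 30000 nM to 300000 nM), corresponding to an expected step of a number no higher from compound 1 to compound 4 (the limit leaves the size open).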

Compound 4, half-maximal inhibitory concentration: > 100000 nM
Compound 4 ended at the assay's limit; the forecaster's own chance of this, stated with the estimate: 60%; the middle value lies on the limit itself.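

Compound 1 and compound 4 both end at a limit of the assay rather than at a number, so no step can be read between them: the limit of > 100000 nM in this assay, at which 3 of the 4 values shown sit.

The compounds shown leave open how naphthalen-1-yl in place of thiophen-2-yl on the carbonyl carbon shifts the result in this assay.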